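This account rests on a few compounds, and the source may have more. Where it says the series, first, only, none or still open, it means among the compounds named here.

Series notes, an ADME assay on THP-1 cells (Homo sapiens) for cytotoxicity, read by flow cytometry and propidium iodide staining, with a stated time of 72 h; on this read-out higher numbers stand for weaker inhibition and lower numbers for stronger inhibition.

Compound 1 `Cn1cnc(CS(=O)(=O)c2ccc(Br)cc2)c1[N+](=O)[O-]`: > 694000 nM, a limit of the assay.
Compound 2 `Cc1nc(CS(=O)(=O)c2ccc(Br)cc2)c([N+](=O)[O-])n1C`: 326000 nM.
Compound 3 `Cc1nc(CS(=O)(=O)c2ccccc2)c([N+](=O)[O-])n1CC(C)O`: 418000 nM.

The change from compound 1 to compound 2 is methyl in place of hydrogen on an aromatic carbon. It brings an at least 2.1-fold lower number from compound 1 to compound 2 (0.32 log units; beyond the scatter); the size is only a lower bound, since compound 1 sits at the limit of > 694000 nM in this assay, at which 1 of the 3 values shown sits. Compound 3 and compound 2 give numbers within the usual scatter of each other. The difference between the core of compound 3 and the core of compound 1 is not broken down here.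

Compound 4 `Cc1ccc(S(=O)(=O)Cc2nc(C)n(CC(C)O)c2[N+](=O)[O-])cc1` is not yet measured in this assay. It differs from compound 3 by methyl in place of hydrogen on an aromatic carbon, the same kind of change as the earlier one but at another place: there the methyl entered a five-membered aromatic ring with two nitrogen, between two ring nitrogen atoms; here it enters a six-membered aromatic ring of carbon only, para to a large group. A step of a 1.5-fold lower number from compound 3 to compound 4 (0.17 log units; within the scatter) is expected, smaller than the earlier step, because an at least 2.1-fold lower number from compound 1 to compound 2 (0.32 log units; beyond the scatter) was seen at a different place of the core. Compound 4 is estimated at 280000 nM, expected to fall between 120000 nM and 620000 nM.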

Compound 4, half-maximal inhibitory concentration: > 707000 nM
Compound 4 gave a limit, no number; the forecaster's own chance of this, stated with the estimate: 15%; at least 2.5-fold (0.40 log units) between middle value and limit.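

In this assay compound 4 gives > 707000 nM, which is a limit of the assay and not a number. Set beside the earlier step, an at least 1.6-fold higher number from compound 3 to compound 4 (0.22 log units; that floor lies within the scatter) runs the other way, so methyl in place of hydrogen does not carry over as one fixed shift across these cores: the same change on two cores in this assay, an at least 2.1-fold lower number (0.32 log units; beyond the scatter) from compound 1 to compound 2 and an at least 1.6-fold higher number (0.22 log units; that floor lies within the scatter) from compound 3 to compound 4, at least 3.6-fold (0.55 log units) apart, beyond the scatter of two such steps

Neither step has a true size, as each rests on a limit, and the two pairs differ both in core and in the ring that takes the methyl, so the gap cannot be assigned to one or the other.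

Open, on these data alone, is how the read-out responds to another group in place of that methyl on the six-membered ring, such as an amine or a carboxylic acid. Also open, as far as these compounds go, is whether the methyl on the six-membered ring gives the same result on the core of compound 2.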